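From 5-methoxypyridin-2-yl to pyrimidin-4-yl at a limit

The compounds below may be only part of what the source reports. "The series", "measured", "known", "first", "only" and "open" are said of these compounds alone.

Of the compounds shown here, two sharing one core have been measured in a physicochemical assay for solubility, using the shake flask method, in phosphate buffer, measured as kinetic solubility, with a stated time of 20 h, at pH 6.5; a lower number here means a less soluble compound, a higher number a more soluble compound. Compound 1 (`FC(F)(F)c1cccc(-c2nc3cnc(Nc4ccccn4)cc3[nH]2)c1`) gives < 5000 nM, which is a limit and not a number. Compound 2 (`COc1ccc(Nc2cc3[nH]c(-c4cccc(C(F)(F)F)c4)nc3cn2)nc1`) gives < 5000 nM, which is also a limit, so compound 2 has no exact number of its own. Compound 3 (`FC(F)(F)c1cccc(-c2nc3cnc(Nc4ccncn4)cc3[nH]2)c1`) has not yet been measured. Its difference from compound 2 is pyrimidin-4-yl in place of 5-methoxypyridin-2-yl on a nitrogen on an aromatic ring. Among the compounds with values here, the only measured step that bears on this change is a step that the two limits leave unreadable from compound 1 to compound 2, and its size cannot be read because of the limit of < 5000 nM in this assay, at which 2 of the 2 values shown sit. Within the data shown here, no measured step exchanges one ring for another, so neither a size nor a direction carries over. The expected step that the limit leaves unreadable from compound 2 to compound 3 is therefore only a loose estimate, with no firm direction. Compound 3 is expected to return a limit as well. For compound 3 the estimated value in this assay is 4000 nM, with an expected range from 1500 nM to 12000 nM.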

Compound 3, solubility: < 5000 nM
Compound 3 gave a limit, no number; the forecaster's own chance of this, stated with the estimate: 70%; the middle value does not contradict the limit.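

In this assay compound 3 gives < 5000 nM, which is a limit and not a number. No step among compound 1, compound 2 and compound 3 can therefore be read: the limit of < 5000 nM in this assay, at which 3 of the 3 values shown sit.

The compounds shown leave open how the pyridin-2-yl, 5-methoxypyridin-2-yl and pyrimidin-4-yl groups compare in this assay.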